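The compounds below may be only part of what the source reports. "The series", "measured", "known", "first", "only" and "open" are said of these compounds alone.

Within the data shown here, in a functional assay on QGY-7703 cells (Homo sapiens) for cytotoxicity, read by MTT assay, with a stated time of 24 h (on this read-out higher numbers stand for weaker inhibition and lower numbers for stronger inhibition), compound 1 (`Cc1ccc(S(=O)(=O)N2C/C(=C\c3cccnc3)C(=O)/C(=C/c3ccccc3F)C2)cc1`) gives 9700 nM and compound 2 (`Cc1ccc(S(=O)(=O)N2C/C(=C\c3cccnc3)C(=O)/C(=C/c3ccccc3C(F)(F)F)C2)cc1`) gives 6170 nM, so compound 2 stands within the scatter of its only neighbour. Compound 3 (`N#Cc1ccc(S(=O)(=O)N2C/C(=C\c3cccnc3)C(=O)/C(=C/c3ccccc3C(F)(F)F)C2)cc1`) differs from compound 2 by one change: cyano in place of methyl on an aromatic carbon. Among the measured compounds shown here, the one measured step, a 1.6-fold lower number from compound 1 to compound 2 (0.20 log units; within the scatter), concerns trifluoromethyl in place of fluoro and says nothing direct about this change, so no step beyond the scatter is expected in this assay. The value expected for compound 3 is 6000 nM, with an estimated range of 2500 nM to 14000 nM. This estimate means an expected 1.0-fold lower number from compound 2 to compound 3 (0.01 log units; within the scatter).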

Compound 3, half-maximal inhibitory concentration: 6150 nM
For compound 3 the middle estimate is 1.0-fold (0.01 log units) below the measured one, within the range that was stated.
By their numbers in this assay, from the lowest: compounds 3, 2 and 1 (each within the scatter of the next).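

Going from 4-methylphenyl to 4-cyanophenyl gives a 1.0-fold lower number from compound 2 to compound 3 (0.00 log units; within the scatter) in this assay. The earlier pair varied only the fluoro and trifluoromethyl group, whereas this step shows that the (4-methylphenyl)sulfonyl part can take cyano in place of methyl with no change beyond the scatter. Nothing available accounts for this result. The compounds shown leave open whether an amine or a carboxylic acid on this same aromatic carbon would also stay within the scatter. They also leave open whether cyano would behave alike with the fluoro group of compound 1 in place of trifluoromethyl.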